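The compounds below may be only part of what the source reports. "The series", "measured", "known", "first", "only" and "open" are said of these compounds alone.

In an ADME assay on MT4 cells (Homo sapiens) for cytotoxicity, read by MTT assay, with a stated time of 4 days (a higher number here means that more compound is tolerated, a lower number that less compound is tolerated), three compounds have been measured so far:

Compound 1 `N#Cc1ccc(Nc2nc(Oc3ccc(F)cc3)c3ccccc3n2)cc1`: > 351000 nM, a limit of the assay rather than a number.
Compound 2 `COc1cc(C#N)ccc1Oc1nc(Nc2ccc(C#N)cc2)nc2ccccc12`: >= 140000 nM, likewise a limit.
Compound 3 `N#Cc1ccc(Nc2nc(Oc3c(Br)cc(Br)cc3Br)c3ccccc3n2)cc1`: 58000 nM.

Going by the values given here, compound 3 is thus the only compound with a real number; the other two values are limits. Compound 4 `Cc1cc(C)c(Oc2nc(Nc3ccc(C#N)cc3)nc3ccccc23)c(C)c1` differs from compound 3 by 2,4,6-trimethylphenyl in place of 2,4,6-tribromophenyl on an oxygen on an aromatic ring. Two measured steps lead into compound 3 at that same oxygen: an at least 6.0-fold lower number from compound 1 to compound 3 (0.78 log units; beyond the scatter) and an at least 2.4-fold lower number from compound 2 to compound 3 (0.38 log units; beyond the scatter), each lowering the number, so the tribromophenyl is the least tolerated of the three groups seen. Swapping it for trimethylphenyl is therefore expected to raise the number again in this assay, by an estimated 2.6-fold higher number from compound 3 to compound 4 (0.41 log units; beyond the scatter). Compound 4 is estimated at 150000 nM, with a range of 50000 nM to 350000 nM.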

Compound 4, half-maximal cytotoxic concentration: > 34000 nM
Compound 4: no number, only a limit; the forecaster's own chance of this, stated with the estimate: 40%; the middle value is on the limit's open side.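

Compound 4 gives only a limit in this assay, so its steps from compound 1, compound 2 and compound 3 cannot be read. On these data alone, whether 2,4,6-trimethylphenyl is better tolerated than 2,4,6-tribromophenyl remains open.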